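Swapping imidazole for triazole on an aromatase inhibitor

The source may report more compounds than this note shows. Statements on the series, on what has been measured and on what is new or still open speak of the compounds shown alone.

Measured compounds:
- compound 1, `Fc1ccc(-c2[nH]c3cc(F)ccc3c2Cn2ccnc2)cc1`: 51.2 nM
- compound 2, `Fc1ccc2c(Cn3ccnc3)c(-c3ccc(Cl)cc3)[nH]c2c1`: 82.9 nM

Both numbers come from an assay on isolated protein for inhibition of Aromatase (Homo sapiens), read by ELISA, using NADPH, with a stated time of 24 h; on this read-out lower numbers stand for stronger inhibition and higher numbers for weaker inhibition. Among the measured compounds shown here, compound 1 and compound 2 share one core and differ only in a halogen on an aromatic carbon; the step of a 1.6-fold higher number from compound 1 to compound 2 (0.21 log units; within the scatter) separates them, so the two compounds stand side by side on the numbers known so far, with compound 1 holding the nearer of the two.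

Compound 3, `Fc1ccc(-c2[nH]c3cc(F)ccc3c2Cn2cncn2)cc1`, keeps the fluoro of compound 1 and changes the five-membered ring on the chain instead: 1H-1,2,4-triazol-1-yl in place of 1H-imidazol-1-yl on a saturated chain carbon bound to an aromatic carbon.

For the measured compounds named here, no measured step touches this kind of change. Going by the values given here, the only step known, the halogen swap a 1.6-fold higher number from compound 1 to compound 2 (0.21 log units; within the scatter), concerns a different part of the molecule and says nothing about the ring on the chain. The expectation for compound 3 therefore rests on compound 1 alone, with a wide range around it. The step of a 1.4-fold higher number from compound 1 to compound 3 (0.14 log units; within the scatter) is expected, which means no change beyond the scatter is foreseen. In this assay compound 3 is estimated at 70 nM, between 20 nM and 250 nM.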

Compound 3, half-maximal inhibitory concentration: 54.4 nM
The estimate for compound 3 lay 1.3-fold (0.11 log units) above the measured number; the range from low to high includes it.
By their numbers in this assay, from the lowest: compounds 1, 3 and 2 (each within the scatter of the next).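

In this assay, among the compounds shown here, the ring on the chain can now be read for the first time, and the result is a 1.1-fold higher number from compound 1 to compound 3 (0.03 log units; within the scatter). The earlier pair spoke only of the halogen on an aromatic carbon, whereas this pair shows that, on a saturated chain carbon bound to an aromatic carbon, 1H-imidazol-1-yl and 1H-1,2,4-triazol-1-yl stand level, even though the count of ring nitrogens goes from 2 to 3 and the count of hydrogen-bond acceptors does the same. Nothing available explains why these two rings read alike, so the finding remains a plain observation about two compounds and one assay.

The compounds shown leave open whether 1H-1,2,4-triazol-1-yl would read the same alongside the chloro of compound 2, since no pair tests the two changes together. They also leave open how far this position stretches beyond these two rings: an amine or a carboxylic acid in place of the ring, or a longer chain between the ring and the shared core, could show whether a five-membered aromatic ring is needed there at all.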